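The compounds below may be only part of what the source reports. "The series", "measured", "known", "first", "only" and "open" are said of these compounds alone.

Compound 3 `O=c1ccoc2cc(OCc3cn(Cc4ccccc4F)nn3)ccc12` stands alone among the three measured compounds in giving a number in a functional assay on SW480 cells (Homo sapiens) for cytotoxicity, read by MTT assay, with a stated time of 48 h; on this read-out lower numbers stand for stronger inhibition and higher numbers for weaker inhibition: compound 3 gives 11400 nM. Compound 1 `Cc1ccccc1Cn1cc(COc2ccc3c(=O)ccoc3c2)nn1` reaches only the limit of the assay, and in this assay compound 1 gives > 100000 nM. Compound 2 `O=c1ccoc2cc(OCc3cn(Cc4cccc(F)c4)nn3)ccc12` likewise stops at the limit, and in this assay compound 2 gives > 100000 nM. The step of an at least 8.7-fold lower number from compound 1 to compound 3 (0.94 log units; beyond the scatter) and the step of an at least 8.7-fold lower number from compound 2 to compound 3 (0.94 log units; beyond the scatter) both point the same way, while the step that the two limits leave unreadable from compound 1 to compound 2 cannot be sized because of the limit of > 100000 nM in this assay, at which 2 of the 3 values shown sit. Compound 4 `COc1ccc(Cn2cc(COc3ccc4c(=O)ccoc4c3)nn2)cc1` differs from compound 3 in that (4-methoxyphenyl in place of 2-fluorophenyl on a saturated chain carbon bound to an aromatic nitrogen). Both measured steps toward compound 3 show that moving away from a 2-fluorophenyl on this carbon raises the number beyond the scatter, so compound 4 is expected to lose potency in this assay, with an estimated step of an 8.8-fold higher number from compound 3 to compound 4 (0.94 log units; beyond the scatter). Compound 4 is therefore estimated at 100000 nM, within a range from 25000 nM to 400000 nM, and it may well report only a limit.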

Compound 4, half-maximal inhibitory concentration: 20400 nM
Compound 4: the middle estimate sits 4.9-fold (0.69 log units) above what was measured; measured number outside the range, below it.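

In this assay, a number at this saturated chain carbon bound to an aromatic nitrogen is not unique to 2-fluorophenyl: replacing it with 4-methoxyphenyl gives a 1.8-fold higher number from compound 3 to compound 4 (0.25 log units; within the scatter) and leaves the two groups indistinguishable. The same 4-methoxyphenyl, set against the other two groups, gives an at least 4.9-fold lower number from compound 2 to compound 4 (0.69 log units; beyond the scatter) and an at least 4.9-fold lower number from compound 1 to compound 4 (0.69 log units; beyond the scatter), so fluorine is neither required for a measurable number nor sufficient for one, as the 3-fluorophenyl of compound 2 goes against it. From the compounds shown here alone, the true size of these last two steps stays unknown because compound 1 and compound 2 stop at a limit: the limit of > 100000 nM in this assay, at which 2 of the 4 values shown sit.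

The compounds shown leave open whether a measurable number survives with an amine or a carboxylic acid on this phenyl ring, or with a longer chain at this carbon. They also leave open how 4-fluorophenyl or 2-methoxyphenyl would compare, which would help separate the identity of the group from where it sits.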